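Methoxymethoxy change at the low end of the series

The compounds below may be only part of what the source reports. "The series", "measured", "known", "first", "only" and "open" are said of these compounds alone.

Compound 1 `COc1ccc(C[S+]([O-])c2ncccc2C(=O)Nc2ccncc2)c(OC)c1`: 0.84 h
Compound 2 `COc1ccc(C[S+]([O-])c2ncccc2C(=O)Nc2ccncc2)c(OC)c1OC`: 116 h

In an ADME assay (a higher number here means that the compound lasts longer, a lower number that the compound disappears faster), compound 1 stands lowest of the two measured compounds at 0.84 h. Compound 3 `COCOc1cc(OC)ccc1C[S+]([O-])c1ncccc1C(=O)Nc1ccncc1` differs from it by methoxy in place of hydrogen on a saturated chain carbon bound to an oxygen on an aromatic ring. Going by the values given here, the only measured step, a 140-fold higher number from compound 1 to compound 2 (2.14 log units; beyond the scatter), is large, but it places methoxy on an aromatic carbon, so it bears only loosely on this change. A much smaller upward move is expected, with wide margins: a 1.5-fold higher number from compound 1 to compound 3 (0.19 log units; within the scatter). For compound 3 the estimated half-life is 1.3 h, with an expected range from 0.3 h to 10 h.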

Compound 3, half-life: 8.25 h
For compound 3 the middle estimate is 6.3-fold (0.80 log units) below the measured one; measured number inside the range.
By their numbers in this assay, from the lowest: compound 1; then compound 3; then compound 2.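

In this assay the change from methoxy to methoxymethoxy gives a 9.8-fold higher number from compound 1 to compound 3 (0.99 log units; beyond the scatter), so a saturated chain carbon bound to an oxygen on an aromatic ring is also a place where the half-life responds, and the earlier step on an aromatic carbon could not show this. No available data bear on the reason for the rise.

Going by these compounds alone, it remains open whether the rise is specific to the added methoxy, since only this one group stands at this place. A longer chain or an amine there would test that.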